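Adding a Five-Membered Ring to a Potent Binder

The compounds below may be only part of what the source reports. "The series", "measured", "known", "first", "only" and "open" are said of these compounds alone.

Of the compounds shown here, three with a shared core have been measured in an assay on isolated protein for binding affinity to 5-hydroxytryptamine receptor 1D (Homo sapiens); a lower number here means a stronger inhibitor, a higher number a weaker inhibitor. Compound 1 `COc1cc2c(cc1N1C[C@@H](C)N(C)[C@@H](C)C1)N(C(=O)Nc1cccc(C(F)(F)F)c1F)CC2` carries a urea and in this assay gives 158 nM. Compound 2 `COc1cc2c(cc1N1C[C@@H](C)N(C)[C@@H](C)C1)N(C(=O)c1ccc(-c3ccccc3C)cc1)CC2` carries an amide joined to a pair of linked aromatic rings and gives 15.9 nM. Compound 3 `COc1cc2c(cc1N1C[C@@H](C)N[C@@H](C)C1)N(C(=O)c1ccc(-c3cc(C)ncc3C)cc1)CC2` has a different outer ring and lacks the methyl on the saturated ring nitrogen; it gives 501 nM. Compound 2 stands lowest of the three, and both gaps to it, the smaller one to compound 1 and the larger one to compound 3, lie beyond the scatter, so compound 2 is the strongest binder shown.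

Compound 4 `COc1cc2c(cc1N1C[C@@H](C)N(C)[C@@H](C)C1)N(C(=O)c1ccc(-c3ccc(-c4noc(C)n4)cc3C)cc1)CC2` is the next compound. Its change relative to compound 2 is 5-methyl-1,2,4-oxadiazol-3-yl in place of hydrogen on an aromatic carbon. Among the measured compounds shown here, no pair of measured compounds shows this change alone, so its effect cannot be read off from the data. For the measured compounds named here, the one clue is that compound 2, with its linked rings intact, already sits well below the others, and a small added ring on the outer ring seems unlikely to wreck that. Compound 4 is expected to stay near compound 2, with the step from compound 2 to compound 4 estimated at a 1.6-fold higher number from compound 2 to compound 4 (0.20 log units; within the scatter), within or close to the scatter. Compound 4 is therefore estimated at 25 nM, with a likely range from 6 nM to 100 nM.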

Compound 4, inhibition constant: 15.9 nM
Beside the measured number, compound 4's estimate is 1.6-fold (0.20 log units) above it; measured number inside the range.
By their numbers in this assay, from the lowest: compounds 2 and 4 (each within the scatter of the next); then compound 1; then compound 3.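

In this assay, putting 5-methyl-1,2,4-oxadiazol-3-yl in place of hydrogen gives no change at the digits printed from compound 2 to compound 4 (within the scatter), so the two compounds cannot be told apart by this measurement. Among the compounds shown here, this is the first view of this position, an aromatic carbon of a six-membered aromatic ring of carbon only, meta to a methyl group and para to a large group: it can carry a group of 6 heavy atoms, including a five-membered aromatic ring with 3 hetero atoms, and the binding number stays within the scatter of that of the compound bearing only hydrogen there. Nothing among the data shown offers an explanation for this result.

This single replacement does not show how much more can be added at this position, or whether other groups would fare the same, such as an amine, a carboxylic acid or a longer carbon chain. It also leaves open whether the 5-methyl-1,2,4-oxadiazol-3-yl group would give the same result on a compound without the methyl on the saturated ring nitrogen.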